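Pyridin-4-yl for 4-methylphenyl: a step from a limit

The compounds below may be only part of what the source reports. "The series", "measured", "known", "first", "only" and "open" are said of these compounds alone.

In a functional assay on HEK293 cells (Homo sapiens) for cytotoxicity (a higher number here means that more compound is tolerated, a lower number that less compound is tolerated), compound 1 (`COc1ccc([C@H]2CC(=O)N(C(=O)c3ccccc3)C2)cc1OC1CCCC1`) gives > 10000 nM as a limit of the assay and not a number. Compound 2 (`COc1ccc([C@H]2CC(=O)N(c3ccc(C)cc3)C2)cc1OC1CCCC1`) gives > 10000 nM in this assay and this too is only a limit. Among the compounds with values here, the one measured step is a step that the two limits leave unreadable from compound 1 to compound 2 and it has no size that can be read. All that is known about these compounds in this assay is the limit of > 10000 nM in this assay, at which 2 of the 2 values shown sit, and no exact number.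

Compound 3 (`COc1ccc([C@H]2CC(=O)N(c3ccncc3)C2)cc1OC1CCCC1`) differs from compound 2 in one place. The difference is pyridin-4-yl in place of 4-methylphenyl on an amide-type nitrogen in a ring and it puts pyridin-4-yl in place of 4-methylphenyl on an amide-type nitrogen in a ring.

Within the data shown here, no measured step offers a size to carry over, so no step beyond the usual scatter is expected in either direction. The expected step is a step that the limit leaves unreadable from compound 2 to compound 3 and it remains only an estimate. The expectation rests on compound 2 and its limit of > 10000 nM in this series. A reading that is again only a limit is the likeliest outcome. For compound 3 the estimated half-maximal cytotoxic concentration is 15000 nM with 7000 nM to 30000 nM as the expected range.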

Compound 3, half-maximal cytotoxic concentration: > 10000 nM
Compound 3 was reported as a limit; the forecaster's own chance of this, stated with the estimate: 85%; the middle value is on the limit's open side.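

In this assay compound 3 gives > 10000 nM as a limit of the assay and not a number. The steps from compound 1 and from compound 2 to compound 3 cannot be read. The compounds shown leave open at which concentration compound 1, compound 2 or compound 3 would harm these cells, and whether the group on the amide-type nitrogen in a ring changes that concentration.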